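A few compounds are considered here, and "the series" means these few. Any claim that something is new, unique, unknown or untested is made for them only; others in the source may bear on it.

Values in an ADME assay on HEp-2 cells (Homo sapiens) for cytotoxicity; a higher number here means that more compound is tolerated, a lower number that less compound is tolerated:
compound 1 `CC(C)CCn1c(Cn2c(=O)n(C(C)C)c3ccccc32)nc2c(CN)cccc21`: 7000 nM
compound 2 `CC(C)CCn1c(Cn2c(=O)n(C(C)C)c3ccccc32)nc2cc(CO)ccc21`: 31600 nM
compound 3 `COC(=O)c1cccc2c1nc(Cn1c(=O)n(C(C)C)c3ccccc31)n2CCC(C)C`: 49200 nM
compound 4 `CC(C)CCn1c(Cn2c(=O)n(C(C)C)c3ccccc32)nc2c(CCCN)cccc21`: not yet measured

In this assay, compound 3 at 49200 nM and compound 2 at 31600 nM lie within the scatter of each other, and compound 1 shows the lowest number of the three. The next change is 3-aminopropyl in place of methoxycarbonyl on an aromatic carbon, with 3-aminopropyl in place of methoxycarbonyl on an aromatic carbon. Going by the values given here, the one measured step that bears on it is a 7.0-fold higher number from compound 1 to compound 3 (0.85 log units; beyond the scatter), a modest step with methoxycarbonyl in place of aminomethyl. Read in reverse, it points to a lower number, though no measured step covers the longer chain. The expected change is an 8.2-fold lower number from compound 3 to compound 4 (0.91 log units; beyond the scatter), similar in size to that step. Compound 4 is estimated at 6000 nM, with an expected range of 2000 nM to 18000 nM.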

Compound 4, half-maximal cytotoxic concentration: 2340 nM
Compound 4: the middle estimate sits 2.6-fold (0.41 log units) above what was measured, within the range that was stated.
By their numbers in this assay, from the lowest: compound 4; then compound 1; then compounds 2 and 3 (each within the scatter of the next).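

In this assay, the step of a 21-fold lower number from compound 3 to compound 4 (1.32 log units; beyond the scatter) shows that this aromatic carbon can carry a group that lowers the number well past the level of the amine compound 1. The longer amine chain itself counts, with a 3.0-fold lower number from compound 1 to compound 4 (0.48 log units; beyond the scatter) showing that the amine-bearing compounds at this position are not interchangeable. No supporting data bear on why these numbers move.

Open, as far as these compounds go, is whether 2-aminoethyl at the same carbon would give an intermediate number, or whether the trend continues with a longer chain. Also open, from the compounds shown here alone, is how a carboxylic acid or a tertiary amine would behave here.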